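The source may report more compounds than this note shows. Statements on the series, on what has been measured and on what is new or still open speak of the compounds shown alone.

Compound 1 `CCn1nc(C)c2c(C)cc(=O)oc21` is the reference point of this small set. In a functional assay on the whole organism with Mus musculus as the target, in the writhing test (a lower number here means that less compound is needed, a higher number that more compound is needed for the effect), compound 1 gives 24.9 mg/kg, the lowest of the two numbers recorded. Compound 2 `CCCn1nc2oc(=O)cc(C)c2c1C`, which carries a propyl chain on a differently arranged core, gives 72.6 mg/kg in this assay, a higher number that lies beyond the usual scatter. Compound 3 `Cc1cc(O)oc2nnc(CC(=O)O)c1-2` reaches only a limit in this assay, > 100 mg/kg, and is not a number. On the set as a whole: the limit of > 100 mg/kg in this assay, at which 1 of the 3 values shown sits. Among the measured compounds shown here, no pair of measured compounds differs in a single place, so no measured step is available to lean on.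

Compound 4 `Cc1cc(=O)oc2c1c(C)nn2C(C)C` differs from compound 1 by methyl in place of hydrogen on a saturated chain carbon bound to an aromatic nitrogen and a saturated chain carbon. For the measured compounds named here, nothing among the measured compounds isolates such a change, and the nearest comparison, compound 2, also changes the core, so its value cannot be read as a chain effect. The expectation for this assay is therefore a small step, if any, more likely toward a higher number than a lower one, and not clearly beyond the scatter. Compound 4 is expected to give about 35 mg/kg in this assay, within a range from 12 mg/kg to 100 mg/kg. That estimate means a step of a 1.4-fold higher number from compound 1 to compound 4 (0.15 log units; within the scatter), expected to stay within the scatter.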

Compound 4, dose for half-maximal effect: > 100 mg/kg
Compound 4: no number, only a limit; the forecaster's own chance of this, stated with the estimate: 15%; middle value at least 2.8-fold (0.45 log units) from the limit.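

The ethyl to isopropyl change, at a saturated chain carbon bound to an aromatic nitrogen and a saturated chain carbon, gives the series its first single-place step, and in this assay it reads as an at least 4.0-fold higher number from compound 1 to compound 4 (0.60 log units; beyond the scatter). This step lies beyond the scatter, so one added methyl at this place is not a neutral change on the core of compound 1, something that compound 2 could not show while its core also differed. Compound 4 gives only a limit, > 100 mg/kg, so the step has a lower bound but no measured size, and limits now make up a larger share of the set: the limit of > 100 mg/kg in this assay, at which 2 of the 4 values shown sit.

Going by these compounds, what remains open is whether branching at this carbon or the added carbon alone drives the step, and a propyl or butyl chain, or a cyclopropyl group, on the core of compound 1 would help separate the two. The compounds shown also do not tell whether a smaller methyl group at this nitrogen, or an amine at the end of the chain, would bring the number below that of compound 1.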